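This account rests on a few compounds, and the source may have more. Where it says the series, first, only, none or still open, it means among the compounds named here.

Measured so far:
compound 1 `COc1ccc(C(=O)Nc2cccc(-c3oc4cc(-c5ccc(F)cc5)ccc4c(=O)c3O)c2)cc1` with 4820 nM
compound 2 `Cc1ccccc1C(=O)Nc1cccc(-c2oc3cc(-c4ccc(F)cc4)ccc3c(=O)c2O)c1` with 11900 nM
compound 3 `COc1cc(OC)cc(C(=O)Nc2cccc(-c3oc4cc(-c5ccc(F)cc5)ccc4c(=O)c3O)c2)c1` with 2700 nM

In a functional assay on HeLa cells (Homo sapiens) for antiproliferative activity, read by CCK-8 assay, with a stated time of 72 h (a higher number here means a weaker inhibitor, a lower number a stronger inhibitor), compound 2 stands at the top of the three numbers. The step of a 2.5-fold higher number from compound 1 to compound 2 (0.39 log units; beyond the scatter) and the step of a 4.4-fold lower number from compound 2 to compound 3 (0.64 log units; beyond the scatter) both lie beyond the scatter, so compound 2 is the weakest inhibitor of the three. Compound 4 `Cc1cc(C)cc(C(=O)Nc2cccc(-c3oc4cc(-c5ccc(F)cc5)ccc4c(=O)c3O)c2)c1` is the next step from compound 2: 3,5-dimethylphenyl in place of 2-methylphenyl on a carbonyl carbon.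

The step that bears most directly on this change is a 4.4-fold lower number from compound 2 to compound 3 (0.64 log units; beyond the scatter), where 3,5-dimethoxyphenyl took the place of the same 2-methylphenyl on the carbonyl carbon. The step of a 1.8-fold lower number from compound 1 to compound 3 (0.25 log units; within the scatter) adds that the two methoxy-bearing groups sit close together. Within the data shown here, no measured step shows a methyl group at the positions named in the entering group, so the expectation rests on the shared arrangement rather than on the substituent itself. A downward step of a 3.0-fold lower number from compound 2 to compound 4 (0.47 log units; beyond the scatter) is expected, somewhat smaller than the step to compound 3. Compound 4 is therefore estimated at 4000 nM, with a range of 1500 nM to 11000 nM.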

Compound 4, half-maximal inhibitory concentration: 5540 nM
For compound 4 the middle estimate is 1.4-fold (0.14 log units) below the measured one; measured number inside the range.
By their numbers in this assay, from the lowest: compounds 3, 1 and 4 (each within the scatter of the next, the first and the last beyond it); then compound 2.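

In this assay, 3,5-dimethylphenyl on the carbonyl carbon gives a 2.1-fold lower number from compound 2 to compound 4 (0.33 log units; beyond the scatter), so the improvement over 2-methylphenyl does not depend on oxygen in the entering group, since this group is carbon only. The methoxy groups still make a difference between the two 3,5-disubstituted phenyl groups, with a 2.1-fold higher number from compound 3 to compound 4 (0.31 log units; beyond the scatter), whereas a 1.1-fold higher number from compound 1 to compound 4 (0.06 log units; within the scatter) leaves 3,5-dimethylphenyl level with 4-methoxyphenyl. Nothing available here accounts for these differences.

Going by these compounds, it remains open whether 3,5-dichlorophenyl, or a phenyl ring bearing an amine or a carboxylic acid in place of the methyl groups of 3,5-dimethylphenyl, would fall in with these numbers. Also open, on these data alone, is whether a saturated ring such as cyclohexyl on the carbonyl carbon would keep any of this activity.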